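The source may hold more compounds than are shown below. What is called first, only, known or untested is meant among the compounds shown, and "the series" means these compounds.

Measured compounds:
compound 1, `O=C(c1ccc(Cl)cc1)n1c(-c2ccccc2[N+](=O)[O-])nc2ccccc21`, 4.69
compound 2, `O=C(c1ccc([N+](=O)[O-])cc1)n1c(-c2ccccc2[N+](=O)[O-])nc2ccccc21`, 4.79

In a physicochemical assay for acid dissociation, compound 2 gives 4.79, the higher of the two numbers, with compound 1 nearest at 4.69; the two are within the scatter of each other, so neither can be called the one that gives up its proton more readily. Compound 3, `O=C(c1ccccc1)n1c(-c2ccccc2[N+](=O)[O-])nc2ccccc21`, has not yet been measured in this assay. It differs from compound 2 in one place: hydrogen in place of nitro on an aromatic carbon. Among the compounds with values here, the only measured step that bears on this change is the one on the same aromatic carbon, a number 0.10 log units higher from compound 1 to compound 2 (within the scatter), where nitro in place of chloro moved the number by less than the usual scatter. Within the data shown here, nothing among the measured compounds shows a larger response to a change at that position, and there is no direct comparison of hydrogen with nitro there. Compound 3 is therefore expected to give a number close to that of compound 2, with a step of a number 0.14 log units lower from compound 2 to compound 3 (within the scatter) of no clear direction beyond the scatter. The estimate for compound 3 in this assay is 4.65, between 4.35 and 4.95.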

Compound 3, acid dissociation constant: 4.9
The estimate for compound 3 lay 0.25 log units below the measured number; measured number inside the range.
By their numbers in this assay, from the lowest: compounds 1, 2 and 3 (each within the scatter of the next).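

In this assay, hydrogen in place of nitro on this aromatic carbon gives a number 0.11 log units higher from compound 2 to compound 3 (within the scatter), and hydrogen in place of chloro gives a number 0.21 log units higher from compound 1 to compound 3 (within the scatter). Within the data shown here, these are the first direct comparisons at this position with hydrogen, which the earlier pair of compounds could not offer, since both of them carried a substituent there. All three compounds now lie within the scatter of one another, so 4-nitrophenyl, its chloro counterpart and phenyl cannot be told apart in this assay, and this holds for these three groups only.

Nothing given here accounts for these numbers or says what lies behind them. From the compounds shown here alone, it remains open whether an amine, a carboxylic acid or a longer chain on this aromatic carbon would give a step beyond the scatter, and whether a change elsewhere on the shared core would do so.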